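Compound 3 and a 1-methyl-1H-imidazol-4-yl counterpart

The source may hold more compounds than are shown below. What is called first, only, known or untested is meant among the compounds shown, and "the series" means these compounds.

In an in vivo ADME assay on the whole organism (strain 129/SvEvBrd x C57BL/6) for pharmacokinetics, with Mus musculus as the target (on this read-out lower numbers stand for lower oral bioavailability and higher numbers for higher oral bioavailability), compound 3 `OC[C@@H](O)[C@@H](O)[C@H](O)c1c[nH]c(-c2ncc[nH]2)n1` gives 28%. Compound 1 `Cc1nc(-c2nc([C@@H](O)[C@H](O)[C@H](O)CO)c[nH]2)cs1`, with 23%, stands within the scatter of it, while compound 2 `OC[C@@H](O)[C@@H](O)[C@H](O)c1c[nH]c(-c2cscn2)n1` gives 12%. Compound 4 `Cn1cnc(-c2nc([C@@H](O)[C@H](O)[C@H](O)CO)c[nH]2)c1` has 1-methyl-1H-imidazol-4-yl in place of 1H-imidazol-2-yl on an aromatic carbon. Among the measured compounds shown here, three measured steps bear on this change, though none repeats it. Hydrogen in place of methyl gave a number 11 percentage points lower from compound 1 to compound 2 (beyond the scatter), and 1H-imidazol-2-yl in place of 1,3-thiazol-4-yl gave a number 16 percentage points higher from compound 2 to compound 3 (beyond the scatter), both modest. The swap a number 5 percentage points higher from compound 1 to compound 3 (within the scatter) stayed within the scatter. No step beyond the scatter is therefore expected, and the estimated change is a number 3 percentage points lower from compound 3 to compound 4 (within the scatter). For compound 4 the expected value is 25%, with an estimated range from 12% to 38%.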

Compound 4, oral bioavailability: 3%
Compound 4: middle estimate off by 22 percentage points, on the high side; measured number outside the range, below it.
By their numbers in this assay, from the lowest: compounds 4 and 2 (each within the scatter of the next); then compounds 1 and 3 (each within the scatter of the next).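

In this assay, this position proves sensitive to which five-membered aromatic ring it carries: 1-methyl-1H-imidazol-4-yl in place of 1H-imidazol-2-yl is a step beyond the scatter (a number 25 percentage points lower from compound 3 to compound 4 (beyond the scatter)). The same group in place of 2-methyl-1,3-thiazol-4-yl also goes beyond the scatter (a number 20 percentage points lower from compound 1 to compound 4 (beyond the scatter)), whereas in place of 1,3-thiazol-4-yl it does not (a number 9 percentage points lower from compound 2 to compound 4 (within the scatter)). The two imidazolyl groups therefore do not behave alike here, although both rings hold two hetero atoms. Nothing available gives a reason for these steps. Still open, as far as these compounds go, is whether the methyl or the point of attachment carries the step, which an unmethylated 1H-imidazol-4-yl group would separate.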